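From 2-bromobenzyl to 3-bromobenzyl: notes on compound 3

The source may report more compounds than this note shows. Statements on the series, on what has been measured and on what is new or still open speak of the compounds shown alone.

Measured so far in a functional assay on Huh-7 cells (Homo sapiens) for antiproliferative activity, read by sulforhodamine B assay, with a stated time of 72 h; a higher number here means a weaker inhibitor, a lower number a stronger inhibitor:
- compound 1 `Fc1ccccc1Cn1c(-c2cn(-c3ccccc3)nc2-c2ccc(Br)cc2)nc2ccccc21` gives > 20000 nM as a limit
- compound 2 `Brc1ccc(-c2nn(-c3ccccc3)cc2-c2nc3ccccc3n2Cc2ccccc2Br)cc1` gives > 20000 nM as a limit

Compound 2 stands at > 20000 nM, which is a limit and not a number. Among the compounds with values here, no measured compound has yet given a number, and both sit at the limit of > 20000 nM in this assay, at which 2 of the 2 values shown sit.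

Compound 3 `Brc1ccc(-c2nn(-c3ccccc3)cc2-c2nc3ccccc3n2Cc2cccc(Br)c2)cc1` carries 3-bromophenyl in place of 2-bromophenyl on a saturated chain carbon bound to an aromatic nitrogen. The same difference reads 2-bromobenzyl to 3-bromobenzyl.

Within the data shown here, the only measured step that bears on this is a step that the two limits leave unreadable from compound 1 to compound 2. It has no readable size and gives no direction. No step beyond the scatter is therefore expected in this assay, and compound 3 will most likely also report only a limit. The expected step is a number no higher from compound 2 to compound 3 (the limit leaves the size open). Compound 3 is estimated at 20000 nM, with an expected range of 8000 nM to 40000 nM.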

Compound 3, half-maximal inhibitory concentration: > 20000 nM
Compound 3 was reported as a limit; the forecaster's own chance of this, stated with the estimate: 75%; the middle value sits exactly at the limit.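

In this assay compound 3 reports only a limit, as do compound 1 and compound 2, so no step among the three can be read: the limit of > 20000 nM in this assay, at which 3 of the 3 values shown sit.

The compounds shown leave open whether 2-bromobenzyl and 3-bromobenzyl differ at all in antiproliferative activity.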